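The source may report more compounds than this note shows. Statements on the series, on what has been measured and on what is new or still open speak of the compounds shown alone.

Compound 1 `COc1cccc(Cc2cc(-c3ccccc3)nn(CC(=O)Nc3ccc(F)cc3)c2=O)c1`: in an assay on HL-60 cells for agonist activity at N-formyl peptide receptor 3 (Homo sapiens), read by calcium flux (a lower number here means that less compound is needed, a higher number that more compound is needed for the effect), compound 1 gives > 50000 nM, which is a limit of the assay.
Compound 2 `COc1cccc(Cc2cc(-c3ccc(Cl)cc3)nn(CC(=O)Nc3ccc(F)cc3)c2=O)c1`: in this assay compound 2 gives > 50000 nM, again a limit.
Compound 3 `Cc1cc(Cc2cccc(F)c2)c(=O)n(CC(=O)Nc2ccc(Br)cc2)n1`: in this assay compound 3 gives > 50000 nM, also a limit.

Compound 3 stands where the other two stand, at the limit of > 50000 nM in this assay, at which 3 of the 3 values shown sit; no measured number separates it from compound 1 or compound 2. Among the compounds with values here, the only step between measured compounds, a step that the two limits leave unreadable from compound 1 to compound 2, is left unreadable by the two limits, and in any case it concerns a different place in the structure.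

Compound 4 `Cc1cc(N)c(=O)n(CC(=O)Nc2ccc(Br)cc2)n1` differs from compound 3 by amino in place of 3-fluorobenzyl on an aromatic carbon. Within the data shown here, no measured step bears on this change, and the data hold no number that could show a direction for it. With every measured compound at the limit of this assay, compound 4 is expected to stay at that limit as well, with an estimated 60000 nM and a range of 15000 nM to 250000 nM. For compound 4 this amounts to an expected step that the limit leaves unreadable from compound 3 to compound 4.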

Compound 4, half-maximal effective concentration: > 50000 nM
Compound 4 gave a limit, no number (the forecaster's own chance of this, stated with the estimate: 85%); the middle value is on the limit's open side.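

In this assay compound 4 gives > 50000 nM, which is a limit. No step between compound 3 and compound 4 can be read, and all values shown coincide: the limit of > 50000 nM in this assay, at which 4 of the 4 values shown sit.

The compounds shown leave open which structure, if any, would give a measurable value in this assay.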